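A few compounds are considered here, and "the series" means these few. Any claim that something is new, unique, unknown or untested is made for them only; others in the source may bear on it.

Measured compounds in the series:

Compound 1, `NC(=[Se])N/N=C/c1csc(-c2ccccc2)n1`, in a functional assay on HepG2 cells (Homo sapiens) for cytotoxicity, read by XTT assay, with a stated time of 72 h (on this read-out higher numbers stand for weaker inhibition and lower numbers for stronger inhibition), gives 9180 nM.
Compound 2, `COc1ccc(/C=N/N(C(C)=O)c2nc(C)c[se]2)cc1`, in this assay gives > 74300 nM, which is a limit of the assay and not a number.
Compound 3, `CC(=O)N(C(=O)c1ccccc1)N(C(C)=O)c1nc(C)c[se]1`, in this assay gives > 68600 nM, again a limit of the assay and not a number.

Compound 3 therefore stands at the limit of > 68600 nM in this assay, at which 1 of the 3 values shown sits; no number is known for it. Compound 2 likewise sits at the limit of > 74300 nM in this assay, at which 1 of the 3 values shown sits. Among the compounds with values here, of the three, only compound 1 gives a number in this assay, and it carries a phenyl on its own five-membered ring; no step between compound 1 and compound 3 is available, so the two values only show that compound 1 gives a number and compound 3 does not.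

The next compound, compound 4, `CC(=O)N(C(=O)c1ccccc1)N(C(C)=O)c1nc(-c2ccccc2)c[se]1`, is made from compound 3 by phenyl in place of methyl on an aromatic carbon. Both acetyl groups and the benzoyl group on the hydrazine are kept. Within the data shown here, no measured step of this kind exists, so the direction is open; with compound 3 at a limit, any movement to stronger inhibition would have to be large to be seen, and the most likely outcome is another limit.

The step from compound 3 to compound 4 is expected to be an at least 1.1-fold lower number from compound 3 to compound 4 (0.05 log units; that floor lies within the scatter), with no firm direction. Compound 4 is estimated at 60000 nM in this assay, expected to fall between 15000 nM and 150000 nM, and quite possibly reported only as a limit.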

Compound 4, half-maximal inhibitory concentration: > 58600 nM
Compound 4 ended at the assay's limit; the forecaster's own chance of this, stated with the estimate: 60%; the middle value does not contradict the limit.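

In this assay compound 3 gives > 68600 nM, a limit of the assay and not a number. Compound 4 gives > 58600 nM, again a limit and not a number, so no step can be read between compound 3 and compound 4. The compounds shown leave open whether phenyl in place of methyl on an aromatic carbon changes the read-out at all.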